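The compounds below may be only part of what the source reports. "The series", "measured", "known", "first", "only" and "open" are said of these compounds alone.

Measured so far:
- compound 1 `CN1CCN(c2cc(C(F)(F)F)nc(SCc3ccc(C(F)(F)F)cc3)n2)CC1`: 23900 nM
- compound 2 `FC(F)(F)c1ccc(CSc2nc(N3CCN(c4ncccn4)CC3)cc(C(F)(F)F)n2)cc1`: 18300 nM
- compound 3 `FC(F)(F)c1ccc(CSc2nc(Sc3ccccn3)cc(C(F)(F)F)n2)cc1`: 23900 nM

Among the measured compounds shown here, in a functional assay on NCI-H1975 cells (Homo sapiens) for inhibition, read by MTT assay, with a stated time of 72 h (a higher number here means a weaker inhibitor, a lower number a stronger inhibitor), compound 1 sits level with compound 3, and compound 2 differs from it only by a 1.3-fold lower number from compound 1 to compound 2 (0.12 log units; within the scatter), so the three values lie within the scatter of one another; no compound can be set apart.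

Compound 4 `FC(F)(F)c1ccc(CSc2nc(Sc3nncs3)cc(C(F)(F)F)n2)cc1` carries the change ((1,3,4-thiadiazol-2-yl)sulfanyl in place of 4-methylpiperazin-1-yl on an aromatic carbon). For the measured compounds named here, the one step that bears on it is the exchange at the same aromatic carbon, no change at the digits printed from compound 1 to compound 3 (within the scatter), which gave no shift beyond the scatter. Going by the values given here, only this single comparison is available, so the basis is thin. The expected step is a 1.0-fold lower number from compound 1 to compound 4 (0.02 log units; within the scatter) because no change at the digits printed from compound 1 to compound 3 (within the scatter) is the nearest guide. Compound 4 is therefore estimated at 23000 nM, with a range of 10000 nM to 50000 nM.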

Compound 4, half-maximal inhibitory concentration: 2270 nM
Estimate against measurement, compound 4: 10-fold (1.01 log units) above, outside the stated range (below it).
By their numbers in this assay, from the lowest: compound 4; then compounds 2, 1 and 3 (each within the scatter of the next).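

In this assay, the aromatic carbon of the shared core responds to its substituent after all: (1,3,4-thiadiazol-2-yl)sulfanyl in place of 4-methylpiperazin-1-yl gives an 11-fold lower number from compound 1 to compound 4 (1.02 log units; beyond the scatter). With the sulfur kept, the ring on it also counts, as 1,3,4-thiadiazol-2-yl in place of pyridin-2-yl gives an 11-fold lower number from compound 3 to compound 4 (1.02 log units; beyond the scatter). No data at hand explain this gain. Still open, on these data alone, is whether the gain depends on the sulfur link or on the ring alone, and whether a 1,3,4-oxadiazol-2-yl or 1,2,4-triazol-3-yl ring on the same sulfur would keep it.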